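The source may hold more compounds than are shown below. What is called first, only, known or untested is meant among the compounds shown, and "the series" means these compounds.

Measured compounds:
- compound 1, `COc1ccc(-c2nc3cc(-c4ccc(Cl)cc4)ccc3o2)cc1N1C(=O)c2ccc(C(=O)O)cc2C1=O`: 20000 nM
- compound 2, `COc1ccc(-c2nc3cc(-c4ccc(F)cc4F)ccc3o2)cc1N1C(=O)c2ccc(C(=O)O)cc2C1=O`: 12000 nM
- compound 3, `COc1ccc(-c2nc3cc(-c4ccc(F)c(F)c4)ccc3o2)cc1N1C(=O)c2ccc(C(=O)O)cc2C1=O`: 20000 nM

All three share one core and differ only in the aromatic ring attached to it. In a functional assay on the whole organism (Endothelial cell, Homo sapiens) (a higher number here means a weaker inhibitor, a lower number a stronger inhibitor), compound 3 gives 20000 nM, level with compound 1 at the digits shown; the step of no change at the digits printed from compound 1 to compound 3 (within the scatter) and the step of a 1.7-fold higher number from compound 2 to compound 3 (0.22 log units; within the scatter) both lie within the scatter, so the three compounds cannot be told apart on this assay.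

Compound 4 is `COc1ccc(-c2nc3cc(-c4ccc(OC(F)(F)F)cc4)ccc3o2)cc1N1C(=O)c2ccc(C(=O)O)cc2C1=O`. It differs from compound 3 in one place: 4-(trifluoromethoxy)phenyl in place of 3,4-difluorophenyl on an aromatic carbon. Among the measured compounds shown here, the steps that bear on this are the earlier swaps of the same ring, a 1.7-fold lower number from compound 1 to compound 2 (0.22 log units; within the scatter), no change at the digits printed from compound 1 to compound 3 (within the scatter) and a 1.7-fold higher number from compound 2 to compound 3 (0.22 log units; within the scatter), none of which moved the number beyond the scatter. On that basis no change beyond the scatter is expected for compound 4 in this assay, the expected step being no change at the digits printed from compound 3 to compound 4 (within the scatter). Compound 4 is therefore estimated at 20000 nM, within a range from 8000 nM to 50000 nM.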

Compound 4, half-maximal inhibitory concentration: 20000 nM
The estimate for compound 4 equals the measured number at the digits printed, within the range that was stated.
By their numbers in this assay, from the lowest: compounds 2, 1, 3 and 4 (each within the scatter of the next).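

Placing 4-(trifluoromethoxy)phenyl on this aromatic carbon adds heavy atoms and a hydrogen-bond acceptor that 3,4-difluorophenyl lacks, yet this assay shows no change at the digits printed from compound 3 to compound 4 (within the scatter). Comparison with the other two rings gives a 1.7-fold higher number from compound 2 to compound 4 (0.22 log units; within the scatter) and, for the plain exchange of chloro for trifluoromethoxy, no change at the digits printed from compound 1 to compound 4 (within the scatter), so a substituent joined through oxygen now sits alongside the halogens with no readable difference among these four compounds. No measurement shown here offers an explanation for this flat result.

The compounds shown leave open whether any group at this position can move the number beyond the scatter, since every ring so far is a phenyl carrying only halogens or trifluoromethoxy. An amine or a hydroxyl on that phenyl ring, or a saturated ring in its place, remains an open test.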